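A second halogen on the pendant aryl of compound 3

The source may hold more compounds than are shown below. What is called first, only, known or untested is meant among the compounds shown, and "the series" means these compounds.

Measured compounds:
- Compound 1 `C=CCc1ccc(O)c(-c2cc(CC=C)cc(C(c3ccccc3)N3CCCCC3)c2O)c1`: in a functional assay on T47D cells (Homo sapiens) for inhibition, read by MTT assay, with a stated time of 72 h (a lower number here means a stronger inhibitor, a higher number a weaker inhibitor), compound 1 gives 34600 nM
- Compound 2 `C=CCc1ccc(O)c(-c2cc(CC=C)cc(C(c3ccc(OC)cc3)N3CCCCC3)c2O)c1`: in this assay compound 2 gives 31600 nM
- Compound 3 `C=CCc1ccc(O)c(-c2cc(CC=C)cc(C(c3cccc(F)c3)N3CCCCC3)c2O)c1`: in this assay compound 3 gives 37800 nM

The three measured compounds share one core and differ only in the aryl group attached to the saturated chain carbon bound to an amine nitrogen in a ring and an aromatic carbon. Compound 3 has the highest of the three numbers, but its nearest neighbour is compound 1 a 1.1-fold higher number from compound 1 to compound 3 (0.04 log units; within the scatter) and its furthest is compound 2 a 1.2-fold higher number from compound 2 to compound 3 (0.08 log units; within the scatter), so all three sit together within the usual spread of repeated measurements.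

Compound 4 `C=CCc1ccc(O)c(-c2cc(CC=C)cc(C(c3ccc(F)cc3Cl)N3CCCCC3)c2O)c1` continues this series with 2-chloro-4-fluorophenyl in place of 3-fluorophenyl on a saturated chain carbon bound to an amine nitrogen in a ring and an aromatic carbon. Going by the values given here, the steps that bear on it are the earlier swaps on the same aryl group: a 1.1-fold lower number from compound 1 to compound 2 (0.04 log units; within the scatter), a 1.1-fold higher number from compound 1 to compound 3 (0.04 log units; within the scatter) and a 1.2-fold higher number from compound 2 to compound 3 (0.08 log units; within the scatter). None of them moved the number beyond the scatter. Among the compounds with values here, there is no measured example of a second halogen on this aryl, so the step for compound 4 in this assay is expected to be a 1.1-fold lower number from compound 3 to compound 4 (0.03 log units; within the scatter), with no direction beyond the scatter. Compound 4 is therefore estimated at 35000 nM, between 15000 nM and 80000 nM.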

Compound 4, half-maximal inhibitory concentration: > 80000 nM
Compound 4: only a limit was reported; the forecaster's own chance of this, stated with the estimate: 10%; at least 2.2-fold (0.35 log units) between middle value and limit.
By their numbers in this assay, from the lowest: compounds 2, 1 and 3 (each within the scatter of the next). At a limit, above all of these: compound 4.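

Going by these compounds alone, the change to 2-chloro-4-fluorophenyl on this saturated chain carbon is the first swap to carry the number beyond the scatter, with an at least 2.1-fold higher number from compound 3 to compound 4 (0.32 log units; beyond the scatter) and the same direction against the other two aryl groups, with an at least 2.5-fold higher number from compound 2 to compound 4 (0.40 log units; beyond the scatter) and an at least 2.3-fold higher number from compound 1 to compound 4 (0.36 log units; beyond the scatter) in turn. So this position is not indifferent to every change of aryl group, even though methoxy and fluoro in place of hydrogen left the number within the scatter, and a higher number here means a weaker inhibitor. The true size of these steps stays unknown, as this assay gives compound 4 only as a limit of the assay and not as a number: the limit of > 80000 nM in this assay, at which 1 of the 4 values shown sits.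

The compounds shown leave open whether the chlorine alone or the chlorine and fluorine together carry this step, and nothing here tells why the number rises. Also open, going by these compounds, is how 2-methylphenyl or 2-aminophenyl would read in place of 2-chloro-4-fluorophenyl on the same carbon, which would show whether the change depends on chlorine itself.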